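From an Oxan-3-yl to a Cyclohexyl Ring

The source may report more compounds than this note shows. Statements on the series, on what has been measured and on what is new or still open speak of the compounds shown alone.

Measured compounds:
compound 1 `CNC(=O)c1cc(C(=O)NC2CC2)cn(CC2CCCOC2)c1=O` — 2
compound 2 `CNC(=O)c1cc(C(=O)NC2CC2)c(C)n(Cc2ccccc2)c1=O` — 2.9

In a physicochemical assay for lipophilicity, at pH 7.4 (on this read-out lower numbers stand for lower lipophilicity and higher numbers for higher lipophilicity), compound 1 gives 2, the lowest of the two numbers. Compound 2 gives 2.9, a higher value that lies beyond the scatter. Among the compounds with values here, no step between measured compounds that differ in one place is available, so the two values show only that difference.

Compound 3 `CNC(=O)c1cc(C(=O)NC2CC2)cn(CC2CCCCC2)c1=O` differs from compound 1 by cyclohexyl in place of oxan-3-yl on a saturated chain carbon bound to an aromatic nitrogen. The step of a number 1.20 log units higher from compound 1 to compound 3 (beyond the scatter) in this assay is expected to be a rise beyond the scatter. Compound 3 is expected to give 3.2, within a range from 2.7 to 3.7.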

Compound 3, distribution coefficient: 4
The estimate for compound 3 lay 0.80 log units below the measured number, and the stated range ends below it.
By their numbers in this assay, from the lowest: compound 1; then compound 2; then compound 3.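

Within the data shown here, replacing oxan-3-yl with cyclohexyl on a saturated chain carbon bound to an aromatic nitrogen gave a number 2.00 log units higher from compound 1 to compound 3 (beyond the scatter) in this assay, the first one-place comparison at this position. The two groups match in heavy-atom count and ring size, so this large step comes with a change of the ring oxygen to carbon alone. No supporting measurement accounts for its size. From the compounds shown here alone, it remains open how an amine in the ring, or a longer chain carrying the cyclohexyl, would read in this assay. Whether the same step would appear on a different core is also unresolved.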